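Piperidinyl for dimethylamino: a one-place change from compound 1

The compounds below may be only part of what the source reports. "The series", "measured", "known", "first", "only" and "open" are said of these compounds alone.

Measured compounds:
compound 1 `CCC(=O)Nc1cccc(Oc2nc(Nc3ccc(N(C)C)cc3OC)ncc2Cl)c1`, 80.6%
compound 2 `CCCN(CCC)c1ccc(Nc2ncc(Cl)c(Oc3cccc(NC(=O)CC)c3)n2)cc1`, 9.3%
compound 3 `CCC(=O)Nc1cccc(Oc2nc(Nc3ccc(N4CCC(C)CC4)cc3)ncc2Cl)c1`, 13.4%

In an assay on isolated protein for inhibition of NUAK family SNF1-like kinase 1 (Homo sapiens), read by ADP-Glo, with a stated time of 60 min, tested at 10 uM, in the presence of a further agent that is not named here (on this read-out lower numbers stand for less inhibition and higher numbers for more inhibition at the one concentration tested (going by the name of the read-out)), compound 1 gives 80.6%, the highest of the three numbers. Compound 3 gives 13.4% and compound 2 gives 9.3%; both gaps from compound 1 are beyond the scatter, and compound 2 stands furthest from it. Compound 4 `CCC(=O)Nc1cccc(Oc2nc(Nc3ccc(N4CCCCC4)cc3OC)ncc2Cl)c1` is not yet measured. It differs from compound 1 in one place: piperidin-1-yl in place of dimethylamino on an aromatic carbon.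

Within the data shown here, the only measured single step in the set, a number 4.1 percentage points higher from compound 2 to compound 3 (within the scatter), exchanges one larger amine for another in compounds that lack the methoxy group and stays within the scatter, so it says nothing about going from dimethylamino to a ring amine. Compounds 2 and 3, with larger amines and no methoxy group, both sit far below compound 1, but each differs from it in two places, so their low values cannot be laid on the amine alone. For compound 4 the expected step is a number 30.6 percentage points lower from compound 1 to compound 4 (beyond the scatter), a moderate loss held with wide uncertainty. Compound 4 is estimated at 50%, between 15% and 85%.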

Compound 4, a percentage reported as inhibition, at one concentration (the size of the read-out at that concentration, not a potency): 13.9%
Beside the measured number, compound 4's estimate is 36.1 percentage points above it; the measured number lies below the stated range.
By their numbers in this assay, from the lowest: compounds 2, 3 and 4 (each within the scatter of the next); then compound 1.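

With the methoxy group held in place, piperidin-1-yl in place of dimethylamino on the aromatic carbon gives, in this assay, a number 66.7 percentage points lower from compound 1 to compound 4 (beyond the scatter), so a change at this position alone is enough to produce a large loss. The earlier compounds shown here could not show this, as compounds 2 and 3 each differ from compound 1 in two places. The swap goes from 3 heavy atoms to 6 and adds a ring while the hydrogen-bond donor and acceptor counts stay the same, but nothing available explains the loss.

From the compounds shown here alone, whether the high value is specific to dimethylamino, or also holds for methylamino, diethylamino, or a smaller ring such as pyrrolidin-1-yl, stays open. Going by these compounds, what the methoxy group contributes on its own also stays open.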